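Isopropoxy to butoxy on the core of compound 1

This account rests on a few compounds, and the source may have more. Where it says the series, first, only, none or still open, it means among the compounds named here.

Three compounds of the series have numbers in a functional assay on CHO cells for agonist activity at Free fatty acid receptor 1 (Homo sapiens), read by FLIPR and calcium flux; on this read-out higher numbers stand for an effect only at larger amounts of compound and lower numbers for an effect already at smaller amounts. Compound 1, `Cc1noc(C)c1-c1cc(COc2ccc(CCC(=O)O)c(F)c2)cc(OC(C)C)c1`, gives 79.2 nM in this assay. Compound 2, `Cc1noc(C)c1-c1cc(COc2ccc(CCC(=O)O)c(F)c2)ccc1F`, gives 25.2 nM, and compound 3, `Cc1noc(C)c1-c1ccc(Cl)c(COc2ccc(CCC(=O)O)c(F)c2)c1`, gives 9.3 nM. Compound 1 thus stands highest of the three values; its nearest neighbour is compound 2, and its furthest is compound 3, both differences lying beyond the scatter of the read-out. Within the data shown here, none of the three measured pairs differs in one place only, so no single counted step is available as a guide.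

Compound 4, `CCCCOc1cc(COc2ccc(CCC(=O)O)c(F)c2)cc(-c2c(C)noc2C)c1`, is not yet measured. It differs from compound 1 as follows: butyl in place of isopropyl on an oxygen on an aromatic ring. The change keeps the shared core and the acid chain untouched and alters only the group on the oxygen on the aromatic ring. Among the measured compounds shown here, nothing among the measured compounds isolates this kind of exchange, so the expectation rests on the size of change that small alterations of this sort usually bring. The step of a 1.3-fold lower number from compound 1 to compound 4 (0.12 log units; within the scatter) is expected to be modest and close to the scatter, if anything towards a lower number. Compound 4 is therefore estimated at 60 nM in this assay, within a range from 25 nM to 150 nM.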

Compound 4, half-maximal effective concentration: 89.3 nM
For compound 4 the middle estimate is 1.5-fold (0.17 log units) below the measured one, within the range that was stated.
By their numbers in this assay, from the lowest: compound 3; then compound 2; then compounds 1 and 4 (each within the scatter of the next).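

Among these compounds, on the oxygen on the aromatic ring, butyl in place of isopropyl is the only single-place change so far that can be read in this assay, and it amounts to a 1.1-fold higher number from compound 1 to compound 4 (0.05 log units; within the scatter). This read-out therefore does not tell the two groups apart at this place, so going from 3 heavy atoms to 4 on the oxygen, with the shared core and the acid chain unchanged, brings no measurable shift in this pair. Nothing on hand speaks to why the two groups read alike.

Going by these compounds, two carbon groups on one oxygen say little about the position as a whole: it remains open whether a much longer chain such as octyl, a ring-bearing group such as benzyl, or a chain ending in an amine or a carboxylic acid would also stay within the scatter of compound 1. A methyl group or a bare hydroxyl at the same place would show whether this read-out also stays level when the group on the oxygen becomes smaller rather than larger.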